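The compounds below may be only part of what the source reports. "The series", "measured", "known", "first", "only" and "open" are said of these compounds alone.

Measured compounds in a physicochemical assay for solubility, in phosphate buffer, at pH 7.4; a higher number here means a more soluble compound, a lower number a less soluble compound:
Compound 1 `CCOC(=O)c1c(-c2cccc(C(F)(F)F)c2)[nH]c2cc(OC)ccc2c1=O` gives 19000 nM.
Compound 2 `CCOC(=O)c1c(-c2cccc(Cl)c2)[nH]c2cc(OC)ccc2c1=O` gives 58000 nM.
Compound 3 `CCOC(=O)c1c(-c2ccc(C(C)(C)C)cc2)[nH]c2cc(OC)ccc2c1=O` gives 2000 nM.

Compound 3 stands lowest of the three numbers. Its nearest neighbour is compound 1, which lies above it by beyond the scatter, and compound 2 lies further above it still. Compound 4 `CCOC(=O)c1c(-c2ccccc2)[nH]c2cc(OC)ccc2c1=O` shares the core of compound 3 and differs from it in one place: hydrogen in place of tert-butyl on an aromatic carbon.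

For the measured compounds named here, no measured step removes a tert-butyl group, so none bears directly on this change. Going by the values given here, the only step between measured compounds, a 3.1-fold higher number from compound 1 to compound 2 (0.48 log units; beyond the scatter), exchanges one group for another on an aromatic carbon of the pendant ring and moves the number modestly. The three values do show that the ring bearing tert-butyl gives the lowest number, while the other two pendant rings give higher ones. Compound 4 is therefore expected to rise from compound 3, by a 20-fold higher number from compound 3 to compound 4 (1.30 log units; beyond the scatter), toward the region of compound 1 and compound 2. Compound 4 is estimated at 40000 nM, with a range from 12000 nM to 130000 nM.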

Compound 4, solubility: > 100000 nM
Compound 4: no number, only a limit (the forecaster's own chance of this, stated with the estimate: 5%); middle value at least 2.5-fold (0.39 log units) from the limit.
By their numbers in this assay, from the lowest: compound 3; then compound 1; then compound 2. At a limit, above all of these: compound 4.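

For compound 4, this assay gives a limit and not a number: the limit of > 100000 nM in this assay, at which 1 of the 4 values shown sits.

Hydrogen in place of tert-butyl on this aromatic carbon gives an at least 50-fold higher number from compound 3 to compound 4 (1.69 log units; beyond the scatter), so a group at this place can carry a large change in the read-out, and the full size of that change is not fixed. Hydrogen in place of trifluoromethyl gives an at least 5.2-fold higher number from compound 1 to compound 4 (0.72 log units; beyond the scatter), while hydrogen in place of chloro gives an at least 1.7-fold higher number from compound 2 to compound 4 (0.23 log units; that floor lies within the scatter), so only the first of these two floors separates the pair beyond the scatter.

On these data alone, what a smaller carbon group such as methyl would do on this aromatic carbon remains open, and so does the outcome with an amine or a carboxylic acid there. The compounds shown also do not say how a longer chain would compare with tert-butyl.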